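Quaternary ammonium head-group swap on the aryloxyheptyl chain

The source may report more compounds than this note shows. Statements on the series, on what has been measured and on what is new or still open speak of the compounds shown alone.

Among the measured compounds shown here, compound 2 `Cc1cc(OCCCCCCC[N+]2(C)CCCCC2)cc(-n2cc(C(=O)Nc3cc(F)cc(F)c3)c(=O)c3ccc(N(C)C)nc32)c1` stands highest of the two numbers so far in an assay on LX2 cells for inhibition of COL1A1 promoter (Homo sapiens), read by a luciferase reporter, with a stated time of 24 h, tested at 50 uM (a higher number here means a stronger effect of the compound at the concentration tested, a lower number a weaker effect), where compound 2 gives 79.7%. Compound 1 `CN(C)c1ccc2c(=O)c(C(=O)Nc3cc(F)cc(F)c3)cn(-c3ccc(Cl)c(OCCCCCCC[N+]45CCN(CC4)CC5)c3)c2n1` gives 18.7%, a gap beyond the scatter. Compound 3 `CC[N+]1(CCCCCCCOc2ccc(-n3cc(C(=O)Nc4cc(F)cc(F)c4)c(=O)c4ccc(N(C)C)nc43)c(C)c2)CCCCC1` is reported as "not active" (no number reported), without a number. For the measured compounds named here, no step between compounds differing in one place is available, so the series offers no direct guide.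

Compound 4 `Cc1cc(OCCCCCCC[N+](C)(C)C2CCCCC2)cc(-n2cc(C(=O)Nc3cc(F)cc(F)c3)c(=O)c3ccc(N(C)C)nc32)c1` differs from compound 2 by a group of 9 heavy atoms (8 carbon, 1 nitrogen; one six-membered non-aromatic ring of carbon only) in place of a group of 7 heavy atoms (6 carbon, 1 nitrogen; one six-membered non-aromatic ring with 1 hetero atom), on a saturated chain carbon, seven bonds along the chain from an oxygen on an aromatic ring. With the charge kept and only the carbon framework around the nitrogen rearranged, a moderate loss, or none beyond the scatter, is expected. The step from compound 2 to compound 4 is estimated as a number 19.7 percentage points lower from compound 2 to compound 4 (beyond the scatter). For compound 4 the expected value is 60%, within a range from 25% to 85%.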

Compound 4, a percentage reported as inhibition, at one concentration (the size of the read-out at that concentration, not a potency): 89.1%
The estimate for compound 4 lay 29.1 percentage points below the measured number; the measured number lies above the stated range.
By their numbers in this assay, from the lowest: compound 1; then compounds 2 and 4 (each within the scatter of the next).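

In this assay, a group with one six-membered non-aromatic ring of carbon only, in place of one with a six-membered non-aromatic ring with 1 hetero atom, gives a number 9.4 percentage points higher from compound 2 to compound 4 (within the scatter). This first single-place step shows that, at this saturated chain carbon, the nitrogen can sit outside the ring with net charge +1 kept and the read-out unchanged within the scatter. No available evidence bears on this result. Open, as far as these compounds go, is whether an uncharged tertiary amine or a carboxylic acid at this position would read alike. From the compounds shown here alone, a longer chain carrying the same cyclohexyl-bearing head group also remains open.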